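Removing one bromo from the dibromo ring of compound 3

A few compounds are considered here, and "the series" means these few. Any claim that something is new, unique, unknown or untested is made for them only; others in the source may bear on it.

Of the compounds shown here, three of the shared core have been measured in a functional assay on U-87MG ATCC cells for inhibition, with U-87 MG (Homo sapiens) as the target, read by MTT assay, with a stated time of 48 h; a lower number here means a stronger inhibitor, a higher number a weaker inhibitor. Compound 1 `COc1cc(/C=N/Nc2nc(-c3ccc(Br)cc3)cs2)cc(Br)c1OC` gives 27900 nM. Compound 2 `COc1cc(/C=N/Nc2nc(-c3cccc(Br)c3)cs2)cc(Br)c1OC` gives 86300 nM. Compound 3 `COc1cc(/C=N/Nc2nc(-c3ccccc3)cs2)c(Br)c(Br)c1OC` gives 20100 nM, the lowest of the three numbers; its gap to compound 1 lies within the scatter, while compound 2 stands higher, beyond the scatter. Among the measured compounds shown here, the single step in the set, a 3.1-fold higher number from compound 1 to compound 2 (0.49 log units; beyond the scatter), concerns the bromophenyl group and does not touch the change considered here. Compound 4 `COc1cc(/C=N/Nc2nc(-c3ccccc3)cs2)cc(Br)c1OC` differs from compound 3 by hydrogen in place of bromo on an aromatic carbon. For the measured compounds named here, no measured pair varies this bromo, so no direct guide exists; compound 1 and compound 3, differing in two places, stand within the scatter of each other, which suggests a small effect. The step expected is a 1.2-fold higher number from compound 3 to compound 4 (0.09 log units; within the scatter), none beyond the scatter. Compound 4 is therefore estimated at 25000 nM, between 10000 nM and 60000 nM.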

Compound 4, half-maximal inhibitory concentration: 74100 nM
Compound 4: middle estimate off by 3.0-fold (0.47 log units), on the low side, and the stated range ends below it.
By their numbers in this assay, from the lowest: compounds 3 and 1 (each within the scatter of the next); then compounds 4 and 2 (each within the scatter of the next).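

In this assay, the bromo para to a methoxy group carries weight: hydrogen in its place gives a 3.7-fold higher number from compound 3 to compound 4 (0.57 log units; beyond the scatter). The same change on the phenyl group depends on where the bromo stands, with a 2.7-fold higher number from compound 1 to compound 4 (0.42 log units; beyond the scatter) for the 4-bromophenyl group, whereas the 3-bromophenyl group gives a 1.2-fold lower number from compound 2 to compound 4 (0.07 log units; within the scatter). Only the 4-bromophenyl bromo therefore shows a step beyond the scatter on that ring.

No supporting data on the origin of these steps are available. Going by these compounds, whether an amine or a methyl group at the position para to a methoxy group would keep the number of compound 3 remains open.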